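The source may report more compounds than this note shows. Statements on the series, on what has been measured and on what is new or still open speak of the compounds shown alone.

Of the compounds shown here, two of a small series have been measured in a functional assay on H9 cells (Homo sapiens); a lower number here means a stronger inhibitor, a higher number a weaker inhibitor. Compound 1, `CC1=CC(=N)C(c2ccccc2)(c2ccccc2)O1`, gives 30 ug/mL in this assay. Compound 2, `O=C1C=C(c2ccccc2)OC1`, gives 38.6 ug/mL in this assay. Compound 2 holds the higher of the two numbers, but its gap to compound 1 lies within the scatter of repeated measurements, so the two cannot be told apart on these values.

The third member, compound 3, `COc1ccccc1C1=CC(=O)CO1`, has not yet been measured in this assay. It differs from compound 2 in one place: methoxy in place of hydrogen on an aromatic carbon. Within the data shown here, no measured pair in this set shows what such a change does, so there is no step to lean on. Without such a guide, the step of a 1.1-fold lower number from compound 2 to compound 3 (0.04 log units; within the scatter) is expected to be small, in neither direction beyond the scatter. Compound 3 is therefore expected to give about 35 ug/mL in this assay, with a likely range from 15 ug/mL to 80 ug/mL.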

Compound 3, concentration for 50% inhibition: 66.3 ug/mL
For compound 3 the middle estimate is 1.9-fold (0.28 log units) below the measured one, within the range that was stated.
By their numbers in this assay, from the lowest: compounds 1, 2 and 3 (each within the scatter of the next, the first and the last beyond it).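

Methoxy on an aromatic carbon of the six-membered aromatic ring of carbon only, ortho to a group of 6 heavy atoms, now supplies the first readable single-place step in this assay (a 1.7-fold higher number from compound 2 to compound 3 (0.23 log units; within the scatter)). The set therefore holds one pair that speaks to this change, and on that pair compound 2 and compound 3 cannot be told apart, so adding methoxy at this place does not separate the two compounds on these values. Nothing shown here bears on why the step has this size.

The compounds shown leave open what a longer chain such as ethoxy, an amine or a carboxylic acid would do at this same place. They also leave open whether methoxy on another carbon of that ring would give a step beyond the scatter.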